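Compound 3: a Chloro Group Enters the Trifluoromethyl Ring

A few compounds are considered here, and "the series" means these few. Any claim that something is new, unique, unknown or untested is made for them only; others in the source may bear on it.

In a functional assay on IGROV-1 cells (Homo sapiens) for inhibition, read by sulforhodamine B assay, with a stated time of 48 h (on this read-out lower numbers stand for stronger inhibition of growth and higher numbers for weaker inhibition of growth), compound 1 `COc1cc(-c2nn(-c3cccc(NC(=O)Nc4cc(C(F)(F)F)cc(C(F)(F)F)c4)c3)cc2-c2ccncc2)ccc1Cl` gives 2190 nM, while compound 2 `COc1cc(-c2nn(-c3cccc(NC(=O)Nc4cccc(C(F)(F)F)c4)c3)cc2-c2ccncc2)ccc1Cl` gives 3110 nM. Within the data shown here, compound 2 thus holds the higher of the two numbers, but the single measured step, a 1.4-fold higher number from compound 1 to compound 2 (0.15 log units; within the scatter), lies within the scatter. Compound 3 `COc1cc(-c2nn(-c3cccc(NC(=O)Nc4ccc(Cl)c(C(F)(F)F)c4)c3)cc2-c2ccncc2)ccc1Cl` differs from compound 2 by chloro in place of hydrogen on an aromatic carbon, on an aromatic carbon ortho to a trifluoromethyl group and para to a large group. Among the measured compounds shown here, that one step is the only guide, and it barely moved the number. The expected step for compound 3 is therefore a 1.4-fold lower number from compound 2 to compound 3 (0.13 log units; within the scatter), probably within the scatter. Compound 3 is estimated at 2300 nM, with a range from 1000 nM to 5500 nM.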

Compound 3, concentration for total growth inhibition: 4220 nM
Compound 3: the middle estimate sits 1.8-fold (0.26 log units) below what was measured; the range from low to high includes it.
By their numbers in this assay, from the lowest: compounds 1, 2 and 3 (each within the scatter of the next).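

In this assay, chloro in place of hydrogen on the aromatic carbon ortho to a trifluoromethyl group and para to a large group gives a 1.4-fold higher number from compound 2 to compound 3 (0.13 log units; within the scatter). The earlier compounds shown here both carried hydrogen on this carbon, and compound 3 now shows that it can carry chloro with no change that stands out from the scatter. No measurement here bears on why this is so.

On these data alone, it remains open whether a carboxylic acid, an amine or a longer chain on this carbon would give a step beyond the scatter.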